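Removing the Para Iodine from a Sulfonamide Antiproliferative

The source may report more compounds than this note shows. Statements on the series, on what has been measured and on what is new or still open speak of the compounds shown alone.

Measured compounds:
compound 1, `CCCCCc1ccc(NS(=O)(=O)c2ccc(N3CCNC3=O)cc2)cc1`: 870 nM
compound 2, `O=C1NCCN1c1ccc(S(=O)(=O)Nc2ccc(I)cc2)cc1`: 260 nM

Both compounds were tested in a functional assay on M21 cells (Homo sapiens) for antiproliferative activity, read by sulforhodamine B assay, with a stated time of 48 h; a higher number here means a weaker inhibitor, a lower number a stronger inhibitor. Among the two numbers, compound 2 gives the lowest, and the only neighbour is compound 1, whose number is higher by a 3.3-fold lower number from compound 1 to compound 2 (0.52 log units; beyond the scatter); that step is the sole measured comparison and it swaps pentyl for iodo on an aromatic carbon of the shared core.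

Compound 3, `O=C1NCCN1c1ccc(S(=O)(=O)Nc2ccccc2)cc1`, has not yet been measured. Its difference from compound 2 is hydrogen in place of iodo on an aromatic carbon. Going by the values given here, the one measured step does not cover this change: it exchanges one group for another, whereas here the group is removed altogether and nothing but hydrogen remains on that aromatic carbon. What the numbers do show is that both measured compounds carry a group at this position, and the two differ by a modest amount. Among the compounds with values here, with no direct precedent, a weaker inhibitor seems more likely than a stronger one, and compound 3 is expected to shift by a 3.5-fold higher number from compound 2 to compound 3 (0.54 log units; beyond the scatter). For compound 3 the estimated value is 900 nM, within a range of 250 nM to 3500 nM.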

Compound 3, half-maximal inhibitory concentration: 200 nM
The estimate for compound 3 lay 4.5-fold (0.65 log units) above the measured number; measured number below the stated range.
By their numbers in this assay, from the lowest: compounds 3 and 2 (each within the scatter of the next); then compound 1.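

In this assay, compound 2 and compound 3 cannot be told apart (a 1.3-fold lower number from compound 2 to compound 3 (0.11 log units; within the scatter)), so on this 4-iodophenyl to phenyl change the iodo group, a single heavy atom para to a large group, is not needed to keep the number seen for compound 2. Until now, every measured compound carried a group at this aromatic carbon, and the plain phenyl of compound 3 shows that hydrogen alone there gives a number in the same range as iodo. Pentyl is the group that stands apart among the three, since the step to hydrogen lies beyond the scatter (a 4.4-fold lower number from compound 1 to compound 3 (0.64 log units; beyond the scatter)), though no measurement at hand explains why these groups compare as they do.

On these data alone, with only hydrogen, iodo and pentyl at this place, it remains open whether a shorter chain such as methyl or ethyl would fall with compound 3 or with compound 1. As far as these compounds go, it also remains open how an amine, a carboxylic acid or a methoxy group at the same carbon would read in this assay.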